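The source may hold more compounds than are shown below. What is called first, only, known or untested is meant among the compounds shown, and "the series" means these compounds.

Measured so far in a functional assay on HCT-116 cells (Homo sapiens) for inhibition, read by CCK-8 assay, with a stated time of 72 h, tested at 8 uM; on this read-out higher numbers stand for more inhibition of growth at the one concentration tested and lower numbers for less inhibition of growth:
- compound 1 `CCc1ccc(SCc2ccc(C(=O)Nc3ccccc3N)cc2)cc1` gives 79.1%
- compound 2 `Nc1ccccc1NC(=O)/C=C/c1ccc(CSc2ccc(F)cc2)cc1` gives 20.2%
- compound 3 `Nc1ccccc1NC(=O)/C=C/c1ccc(CSCCc2ccccc2)cc1` gives 10.6%

Compound 1 holds the highest of the three numbers, and its gaps to compound 2 and compound 3 both lie beyond the scatter. For the measured compounds named here, the next compound to read is compound 4 `Cc1cc(C)cc(SCc2ccc(C(=O)Nc3ccccc3N)cc2)c1`, which has no measurement yet. Its difference from compound 1 is 3,5-dimethylphenyl in place of 4-ethylphenyl on a sulfur, with 3,5-dimethylphenyl in place of 4-ethylphenyl on a sulfur. The two have the same atoms, joined differently.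

Going by the values given here, only one measured step concerns a group on a sulfur: a number 9.6 percentage points lower from compound 2 to compound 3 (within the scatter). That step swaps 4-fluorophenyl for phenethyl on a core other than the core of compound 1, so it bears on the present change only loosely. Among the compounds with values here, no step has been measured on the core of compound 1 itself. On this thin evidence, no step beyond the scatter is expected in this assay. The estimated step is a number 7.1 percentage points lower from compound 1 to compound 4 (within the scatter), and the range is kept wide on the lower side. The expected value for compound 4 is 72%, within an estimated range of 48% to 90%.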

Compound 4, percent growth inhibition at one concentration: 72.9%
For compound 4 the middle estimate is 0.9 percentage points below the measured one; the measured number falls inside the stated range.
By their numbers in this assay, from the lowest: compounds 3 and 2 (each within the scatter of the next); then compounds 4 and 1 (each within the scatter of the next).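

For the compounds shown here, on the core of compound 1, the only measured change on the sulfur, 3,5-dimethylphenyl in place of 4-ethylphenyl, gives in this assay a number 6.2 percentage points lower from compound 1 to compound 4 (within the scatter) and thus the first reading of a group on the sulfur on this core. Moving from one aryl arrangement of eight carbons to the other, with the same atoms joined differently and the sulfur's saturated chain carbon unchanged, does not separate the two compounds on this read-out. This holds for this one pair only, and the step between compound 2 and compound 3 belongs to a different core, so it neither supports nor contradicts the reading. No supporting data are available to explain the result.

Still open, as far as these compounds go, is how the core of compound 1 responds to a more different group on the sulfur, such as a phenyl ring carrying an amine or a carboxylic acid, or a longer chain such as phenethyl. A reading at a single concentration also leaves open whether compound 1 and compound 4 would stay together across a range of concentrations.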